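The source may report more compounds than this note shows. Statements on the series, on what has been measured and on what is new or still open speak of the compounds shown alone.

Measured so far in a functional assay on CHO cells for agonist activity at Free fatty acid receptor 1 (Homo sapiens), read by FLIPR and calcium flux; on this read-out lower numbers stand for an effect already at smaller amounts and higher numbers for an effect only at larger amounts of compound:
- compound 1, `CO/N=C1\CC(CC(=O)O)c2ccc(OCc3cccc(-c4c(C)cc(OC)cc4C)c3)cc21` — compound 1 gives > 1000 nM
- compound 2, `O=C(O)CS(=O)(=O)c1ccc(OCc2cccc(-c3ccccc3F)c2)cc1` — compound 2 gives 257 nM

Within the data shown here, compound 2 holds the only number in this assay. The value of compound 1 is a limit of the assay, not a number, and sits at the limit of > 1000 nM in this assay, at which 1 of the 2 values shown sits. Among the measured compounds shown here, no step between measured compounds can be drawn from these two entries, so nothing about the size of a single change in this assay is yet known from the series itself.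

Compound 3, `CCOc1ccc(-c2cccc(COc3ccc(S(=O)(=O)CC(=O)O)cc3)c2)c(Cl)c1`, is the next compound to be measured. It differs from compound 2 in one place: 2-chloro-4-ethoxyphenyl in place of 2-fluorophenyl on an aromatic carbon. Compound 3 is expected to come out at 120 nM, with a range from 30 nM to 500 nM. The expected step of a 2.1-fold lower number from compound 2 to compound 3 (0.33 log units; beyond the scatter) is estimated as a modest shift toward an effect at smaller amounts, not far beyond the usual scatter.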

Compound 3, half-maximal effective concentration: 51.3 nM
For compound 3 the middle estimate is 2.3-fold (0.37 log units) above the measured one; measured number inside the range.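

Among these compounds, replacing 2-fluorophenyl with 2-chloro-4-ethoxyphenyl on this aromatic carbon, meta to a large group, gives the first step that can be read in this assay: a 5.0-fold lower number from compound 2 to compound 3 (0.70 log units; beyond the scatter) and shows that this position accepts the larger group with the number moving down. The entering group has more heavy atoms and a hydrogen-bond acceptor that the leaving group lacks, but these differences arrive together, so the step cannot be divided among the chlorine, the ethoxy group and the loss of fluorine. Nothing given here bears on the cause of this step.

Still open, from the compounds shown here alone, is how a 2-chlorophenyl group, or a propoxy chain or an amine in place of the ethoxy group, would read in this assay at this position. Also open, going by these compounds, is whether the same change would carry over to the core of compound 1, whose value is only a limit.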